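A few compounds are considered here, and "the series" means these few. Any claim that something is new, unique, unknown or untested is made for them only; others in the source may bear on it.

Compound 1 `O=C1c2ccccc2N(Cc2ccccc2)S(=O)(=O)N1COCc1ccccc1` — > 98000 nM
Compound 2 `O=S1(=O)N=C(OCc2ccccc2)c2ccccc2N1Cc1ccccc1` — > 200000 nM

Both values come from a functional assay on HEL cells (Homo sapiens) for inhibition (a higher number here means that more compound is tolerated, a lower number that less compound is tolerated), and both are limits of the assay rather than numbers. Compound 1 stands at the limit described by the limit of > 98000 nM in this assay, at which 1 of the 2 values shown sits. Compound 2 sits at the other limit, described by the limit of > 200000 nM in this assay, at which 1 of the 2 values shown sits. Among the compounds with values here, with two limits and no number, no step between measured compounds can be drawn; the two results only show that neither compound reached a half-maximal cytotoxic concentration within the tested range. Compound 3 `O=C1c2ccccc2N(Cc2ccccc2)S(=O)(=O)N1Cc1ccc(Cl)cc1` has not yet been measured in this assay. It differs from compound 1 by 4-chlorophenyl in place of benzyloxy on a saturated chain carbon bound to an amide-type nitrogen in a ring. Since compound 1 gives only a limit, the step to compound 3 cannot be anchored to a measured pair. The step that the limit leaves unreadable from compound 1 to compound 3 is expected to be no larger than the usual scatter, in either direction. Compound 3 is expected to give 100000 nM, with a range from 30000 nM to 300000 nM.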

Compound 3, half-maximal cytotoxic concentration: 121000 nM
Estimate against measurement, compound 3: 1.2-fold (0.08 log units) below; the range from low to high includes it.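

The step from compound 1 to compound 3 cannot be read in this assay: the result for compound 1 is a limit of the assay, not a number. The compounds shown leave open whether, and how far, replacing (benzyloxy)methyl with 4-chlorobenzyl shifts the half-maximal cytotoxic concentration.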